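Notes on compound 3: ring-opened ester in place of the lactone

This account rests on a few compounds, and the source may have more. Where it says the series, first, only, none or still open, it means among the compounds named here.

Compound 1 `CC1=C(O)[C@@H](C/C(C)=C\CC[C@H](C)/C=C/C=C(\C)CCCc2ccoc2)OC1=O` is the reference of this small set. In a functional assay on HCT-15 cells (Homo sapiens) for cytotoxicity (a lower number here means that less compound is needed, a higher number that more compound is needed for the effect), compound 1 gives 6.5 ug/mL, the lowest of the two numbers at hand; its nearest neighbour is compound 2 `CCC(C)CN1CC=C(CCC/C(C)=C/C=C/[C@@H](C)CC/C=C(/C)C[C@H]2OC(=O)C(C)=C2O)C1=O`, which in this assay gives 22.3 ug/mL. Going by the values given here, the one measured step, a 3.4-fold higher number from compound 1 to compound 2 (0.54 log units; beyond the scatter), concerns the other end of the chain and was modest.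

Compound 3 `COC(=O)C(O)C/C(C)=C\CC[C@H](C)/C=C/C=C(\C)CCCc1ccoc1` differs from compound 1 as a group of 6 heavy atoms (3 carbon, 3 oxygen; no ring) in place of a group of 8 heavy atoms (5 carbon, 3 oxygen; one five-membered non-aromatic ring with 1 hetero atom), on a saturated chain carbon bound to a double-bonded chain carbon. Among the compounds with values here, no measured step touches this place, so the only guide is the general level of the series. Compound 3 is therefore expected to need somewhat more compound than compound 1, and the step of a 2.8-fold higher number from compound 1 to compound 3 (0.44 log units; beyond the scatter) is the size estimated, though it may well fall within the scatter. The value for compound 3 in this assay is estimated at 18 ug/mL, within a range of 6 ug/mL to 55 ug/mL.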

Compound 3, concentration for half-maximal effect: 8.7 ug/mL
The estimate for compound 3 lay 2.1-fold (0.32 log units) above the measured number; low and high end bracket the measured number.
By their numbers in this assay, from the lowest: compounds 1 and 3 (each within the scatter of the next); then compound 2.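

In this assay, hydroxy(methoxycarbonyl)methyl in place of the five-membered ring gives a 1.3-fold higher number from compound 1 to compound 3 (0.13 log units; within the scatter), so compound 3 cannot be told apart from compound 1 and, for these two compounds, closing the ring at this place makes no measurable difference. Going by these compounds alone, the hydrogen-bond donor and acceptor counts of the two groups are the same, and the only step beyond the scatter remains the change at the other end of the chain, a 3.4-fold higher number from compound 1 to compound 2 (0.54 log units; beyond the scatter). Nothing at hand explains why the ring can be opened here without a clear change in the number.

As far as these compounds go, whether a carboxylic acid or a primary amide in place of the ester would stay at this level remains open, as does the contribution of the hydroxy group. Also open, from the compounds shown here alone, is whether the ring-opened group behaves the same way alongside the chain end of compound 2.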